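The source may report more compounds than this note shows. Statements on the series, on what has been measured and on what is new or still open speak of the compounds shown alone.

Compound 3 `O[C@@H]1[C@@H](OCc2ccccc2)[C@H](OCc2ccccc2)[C@@H](COCc2ccccc2)O[C@H]1c1ccccc1` holds the higher of the two numbers measured in a functional assay on HL-60 cells (Homo sapiens) for antiproliferative activity, read by MTT assay; a higher number here means a weaker inhibitor, a lower number a stronger inhibitor: compound 3 gives 26300 nM, whereas compound 2 `O[C@@H]1[C@@H](OCc2ccccc2)[C@H](OCc2ccccc2)[C@@H](COCc2ccccc2)O[C@H]1Cc1ccccc1` gives 8700 nM, a step of a 3.0-fold higher number from compound 2 to compound 3 (0.48 log units; beyond the scatter). Compound 1 `CC[C@H]1O[C@H](COCc2ccccc2)[C@@H](OCc2ccccc2)[C@H](OCc2ccccc2)[C@H]1O`, which carries an ethyl group, is reported as "not active" (no number reported). Compound 4 `O[C@H]1CO[C@H](COCc2ccccc2)[C@@H](OCc2ccccc2)[C@@H]1OCc1ccccc1` differs from compound 3 in one place: hydrogen in place of phenyl on a saturated ring carbon. For the measured compounds named here, the only measured step that bears on this change is the one from compound 2 to compound 3, a modest weakening when phenyl replaced benzyl, and compound 1 adds that a compound with an ethyl group showed no activity at all. A further weakening, or no measurable activity, is therefore expected, roughly a 2.3-fold higher number from compound 3 to compound 4 (0.36 log units; beyond the scatter). Compound 4 is estimated at 60000 nM, with a range from 20000 nM to 200000 nM.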

Compound 4, half-maximal inhibitory concentration: "not active" (no number reported)
The entry for compound 4 holds no number, and the estimate cannot be compared.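

Compound 4 carries no number, so no step from compound 3 to compound 4 can be read, and nothing at hand explains this result. The compounds shown leave open how much weaker compound 4 is than compound 3.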